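The compounds below may be only part of what the source reports. "The series", "measured", "known", "first", "only" and "open" are said of these compounds alone.

Measured so far in an ADME assay on a cell-free system (plasma, Rattus norvegicus), using equilibrium dialysis, at 37 degrees C (a lower number here means a smaller unbound share, a higher number a larger unbound share of the compound), for two compounds:
- compound 1 `CCCSc1ncccc1C(=O)NC1CCCCC1` gives 0.13
- compound 2 `CCCSc1c(C(=O)NC2CCCCC2)cnn1C` gives 0.132

Compound 2 stands level with compound 1, since their two values lie within the scatter of each other. Compound 3 `CCCSc1c(C(=O)NC2CCCCC2)cnn1-c1cccc(C(=O)O)c1` keeps the rest of compound 2 and carries 3-carboxyphenyl in place of methyl on an aromatic nitrogen. Going by the values given here, no measured pair shows this kind of change, so what follows is a judgement. A large move toward a smaller unbound share is expected, with a 6.6-fold lower number from compound 2 to compound 3 (0.82 log units; beyond the scatter) as the estimated step. For compound 3 the estimate is 0.02 within a range of 0.006 to 0.06 in this assay when measured.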

Compound 3, unbound fraction in the plasma assay: 0.02
Compound 3: the middle estimate sits on the measured number at the digits printed; low and high end bracket the measured number.
By their numbers in the plasma assay, from the lowest: compound 3; then compounds 1 and 2 (each within the scatter of the next).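

In the plasma assay, the aromatic nitrogen proves sensitive to what it carries: 3-carboxyphenyl in place of methyl gives a 6.6-fold lower number from compound 2 to compound 3 (0.82 log units; beyond the scatter). The unbound share falls even though the number in a physicochemical assay for lipophilicity, using the shake flask method, at pH 7.4 (a lower number here means a more polar compound, a higher number a more lipophilic compound), falls too, with compound 2 at 3 and compound 3 at 0.7, so lipophilicity alone does not account for this step: the measured distribution coefficient of compound 2, 3, and of compound 3, 0.7, a number 2.30 log units lower (beyond the scatter)

The aromatic ring and its carboxylic acid enter together, and the compounds shown cannot tell which of them carries the step. A plain phenyl on the same nitrogen would separate the two.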